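Swapping a cyclic sulfonamide for a triazolylmethyl arm

The source may report more compounds than this note shows. Statements on the series, on what has been measured and on what is new or still open speak of the compounds shown alone.

Compound 1 `CC(C)C(c1ccc(-c2ccc3cccc(F)c3c2)[nH]c1=O)N1CCCCS1(=O)=O` was tested in an assay on CHO cells for displacement of a labelled ligand from prostaglandin E2 receptor EP3 subtype (Homo sapiens), read by radioligand binding (on this read-out lower numbers stand for stronger inhibition and higher numbers for weaker inhibition), where compound 1 gives 14 nM. Compound 2 `CCn1ncc2c(F)cc(-c3ccc(C(CC)(CC)c4nnc[nH]4)c(=O)[nH]3)cc21` gives 17 nM in this assay, and the two numbers lie within the usual scatter of one another. Compound 3 `CC(C)C(Cc1nnc[nH]1)c1ccc(-c2ccc3cccc(F)c3c2)[nH]c1=O` has not been measured; it differs from compound 1 by a group of 6 heavy atoms (3 carbon, 3 nitrogen; one five-membered aromatic ring with 3 hetero atoms) in place of a group of 8 heavy atoms (4 carbon, 1 nitrogen, 2 oxygen, 1 sulfur; one six-membered non-aromatic ring with 2 hetero atoms), on a saturated chain carbon bound to an aromatic carbon and a saturated chain carbon. Going by the values given here, no comparable step between measured compounds exists, so the expected step of a 2.1-fold higher number from compound 1 to compound 3 (0.33 log units; beyond the scatter) is a modest weakening, resting on compound 2 carrying a triazole of its own and giving 17 nM. Compound 3 is estimated at 30 nM, within 8 nM to 120 nM.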

Compound 3, inhibition constant: 10 nM
Beside the measured number, compound 3's estimate is 3.0-fold (0.48 log units) above it; low and high end bracket the measured number.
By their numbers in this assay, from the lowest: compounds 3, 1 and 2 (each within the scatter of the next).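

On this saturated chain carbon, replacing the six-membered sulfonyl ring with (4H-1,2,4-triazol-3-yl)methyl gives a 1.4-fold lower number from compound 1 to compound 3 (0.15 log units; within the scatter) in this assay, so two quite different groups are tolerated here. The entering group brings a hydrogen-bond donor that the leaving group lacks, yet the two numbers cannot be told apart. Nothing measured explains this tolerance.

The compounds shown leave open whether an amine, a carboxylic acid or a longer chain on this carbon would also hold the number. They also do not show whether the triazole needs its methylene link.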